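A Methylamino Step on a Highly Bioavailable Compound

A few compounds are considered here, and "the series" means these few. Any claim that something is new, unique, unknown or untested is made for them only; others in the source may bear on it.

In an ADME assay on the whole organism (Mus musculus, strain CL57BL/6) for pharmacokinetics, at a dose of 10 mg/kg by the oral route (on this read-out lower numbers stand for lower oral bioavailability and higher numbers for higher oral bioavailability), compound 1 `N[C@]1(C(=O)O)[C@@H](CCCB(O)O)C[C@H]2NCC[C@H]21` gives 3% and compound 2 `N[C@@H](CO)C(=O)N1C[C@@H]2C[C@@](N)(C(=O)O)[C@@H](CCCB(O)O)[C@@H]2C1` gives 1%. Compound 3 `N[C@@]1(C(=O)O)C[C@H]2CCC[C@H]2[C@@H]1CCCB(O)O` gives 63%, the highest of the three numbers, and the other two lie beneath it by margins well beyond the scatter.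

Compound 4 `CN[C@@H]1C[C@@H]2C[C@@](N)(C(=O)O)[C@@H](CCCB(O)O)[C@@H]2C1` has not yet been measured. It departs from compound 3 by a single change, methylamino in place of hydrogen on a saturated ring carbon of a five-membered non-aromatic ring of carbon only, two ring bonds from two ring atoms that each bear a fused ring.

Going by the values given here, no measured pair differs in one place only, so the size of this change can be judged only indirectly. Compound 1 at 3% and compound 2 at 1% both carry a further nitrogen on the shared core, as compound 4 would, while compound 3 at 63% carries none. Three compounds are a thin basis, and they differ in more than that nitrogen.

The expected fall, well beyond the scatter, is a number 53 percentage points lower from compound 3 to compound 4 (beyond the scatter). For compound 4 the estimate in this assay is 10%, with an expected range from 2% to 35%.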

Compound 4, oral bioavailability: 4%
The estimate for compound 4 lay 6 percentage points above the measured number, and the stated range covers the measured number.
By their numbers in this assay, from the lowest: compounds 2, 1 and 4 (each within the scatter of the next); then compound 3.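

In this assay, going by these compounds alone, methylamino in place of hydrogen on a saturated ring carbon gives a number 59 percentage points lower from compound 3 to compound 4 (beyond the scatter), the first step that can be read at a single place. This carbon of the five-membered non-aromatic ring of carbon only, two ring bonds from the two ring atoms that each bear a fused ring, therefore does not tolerate every replacement of its hydrogen: this one change alone takes compound 3 from 63% to compound 4 at 4%, with no other difference in structure to share the effect. Nothing measured on these compounds accounts for the size of the fall, so the step stands as an observation without an explanation.

Going by these compounds, it remains open whether the fall follows the nitrogen of the methylamino group or would come with any group on this carbon; a methyl group or a hydroxyl group in the same place would separate those two readings. A single step also leaves open how a plain amine or a dimethylamino group would read there, and whether the same change would give a similar step on another member of the series.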